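Swapping a chlorinated ring for a hydroxylated one

The source may report more compounds than this note shows. Statements on the series, on what has been measured and on what is new or still open speak of the compounds shown alone.

Measured so far:
- compound 1 `COc1cccc(/C=C2\CCC/C(=C\c3ccc(Cl)cc3Cl)C2=O)c1OC`: 16300 nM
- compound 2 `COc1ccc(/C=C2\CCC/C(=C\c3ccccc3Cl)C2=O)cc1OC`: 7100 nM

Both compounds share the same core, a ring carbonyl flanked by two double-bonded chain carbons, each carrying an aromatic ring. In a functional assay on SW-620 cells (Homo sapiens) for cytotoxicity, read by MTT assay, with a stated time of 72 h (on this read-out higher numbers stand for weaker inhibition and lower numbers for stronger inhibition), compound 1 gives 16300 nM, while compound 2 gives 7100 nM. Of the two numbers, compound 2 stands at the lower end, and its gap to compound 1 lies beyond the usual scatter of repeated measurements, so compound 2 is the stronger inhibitor of the pair.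

Compound 3 `COc1ccc(/C=C2\CCC/C(=C\c3ccc(O)cc3)C2=O)cc1OC` has not yet been measured in this assay. It differs from compound 2 in one place: 4-hydroxyphenyl in place of 2-chlorophenyl on a double-bonded chain carbon bound to a double-bonded ring carbon. For the measured compounds named here, no pair of measured compounds shows the effect of exactly this exchange, so there is no step in the data to lean on. With a ring that now carries one hydrogen-bond donor and one acceptor where none stood before, the expected step of a 1.4-fold higher number from compound 2 to compound 3 (0.15 log units; within the scatter) is a modest move toward a higher number, possibly no larger than the scatter. Compound 3 is therefore expected to give about 10000 nM, in a range from 3500 nM to 30000 nM.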

Compound 3, half-maximal inhibitory concentration: 7700 nM
Compound 3: middle estimate off by 1.3-fold (0.11 log units), on the high side; measured number inside the range.
By their numbers in this assay, from the lowest: compounds 2 and 3 (each within the scatter of the next); then compound 1.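

In this assay the exchange of 2-chlorophenyl for 4-hydroxyphenyl on a double-bonded chain carbon bound to a double-bonded ring carbon gives a 1.1-fold higher number from compound 2 to compound 3 (0.04 log units; within the scatter) and so leaves the two compounds indistinguishable on this read-out. Compound 1 and compound 2 differ in more than one place, so they could not show what a single ring exchange does; this pair can, and it shows that this position accepts a ring carrying a hydrogen-bond donor and acceptor in place of one carrying neither, with no change beyond the scatter. Nothing measured here explains why the two rings read alike.

This single exchange removes chlorine and brings in hydroxyl while also altering where the ring is substituted, so 2-hydroxyphenyl and 4-chlorophenyl would be needed to tell the effect of the group from the effect of its place. Going by these compounds, whether the position would accept an amine or a carboxylic acid on this ring as readily as it accepts the hydroxyl remains open.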